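Swapping benzyloxy for cyclopropylamino at a tolerated limit

The source may report more compounds than this note shows. Statements on the series, on what has been measured and on what is new or still open speak of the compounds shown alone.

In an ADME assay on MOLT-3 cells (Homo sapiens) for cytotoxicity, with a stated time of 7 days (a lower number here means that less compound is tolerated, a higher number that more compound is tolerated), compound 3, `Nc1nc(OCc2ccccc2)c2ncn(/C=C3/CC3(CO)CO)c2n1`, gives > 20000 nM, which is a limit of the assay and not a number. Compound 1, `CNc1nc(N)nc2c1ncn2/C=C1/CC1(CO)CO`, gives > 20000 nM, also a limit. For compound 2, `CC(C)CSc1nc(N)nc2c1ncn2/C=C1/CC1(CO)CO`, the entry reads "not determined" (no result reported). The set therefore offers (the limit of > 20000 nM in this assay, at which 2 of the 3 values shown sit).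

Compound 4, `Nc1nc(NC2CC2)c2ncn(/C=C3/CC3(CO)CO)c2n1`, still awaits measurement. It differs from compound 3 as follows: cyclopropylamino in place of benzyloxy on an aromatic carbon. The new group is attached through nitrogen, as the methylamino of compound 1 is.

Among the measured compounds shown here, only one measured step bears on this change: a step that the two limits leave unreadable from compound 1 to compound 3. It swaps the same position, but it gives no size to build on, so no step beyond the usual scatter is expected, and no direction can be argued. Compound 1 carries methylamino there and still reaches > 20000 nM, so good tolerance is expected to persist.

The expected change is a step that the limit leaves unreadable from compound 3 to compound 4. Compound 4 is estimated at 25000 nM, with an expected range from 8000 nM to 60000 nM.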

Compound 4, half-maximal cytotoxic concentration: > 20000 nM
Compound 4: no number, only a limit; the forecaster's own chance of this, stated with the estimate: 70%; the middle value is on the limit's open side.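

The steps among compound 1, compound 3 and compound 4 in this assay cannot be read, because all three give only a limit and not a number: the limit of > 20000 nM in this assay, at which 3 of the 4 values shown sit.

As far as these compounds go, how much of each compound is tolerated past that limit, and whether benzyloxy, methylamino and cyclopropylamino differ there at all, stays open.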